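The source may report more compounds than this note shows. Statements on the series, on what has been measured and on what is new or still open speak of the compounds shown alone.

Of the compounds shown here, two carrying the same core have been measured in a functional assay on NCI/ADR-RES cells (Homo sapiens) for cytotoxicity, read by sulforhodamine B assay, with a stated time of 48 h, tested at 100 uM; on this read-out lower numbers stand for a stronger effect and higher numbers for a weaker effect at the one concentration tested. Compound 1 `COc1cc(-c2cc(/C=C/C(=O)c3ccc(Cl)c(Cl)c3)[nH]n2)cc(OC)c1OC` gives 5% in this assay. Compound 2 `COc1ccc(-c2cc(/C=C/C(=O)c3cc(OC)c(OC)c(OC)c3)[nH]n2)cc1OC` gives -7% in this assay. Of these two numbers, compound 1 is the higher one, and the gap to compound 2 is beyond the usual scatter, so compound 1 shows the weaker effect of the two at the single concentration tested, while both sit at the strong end of the scale.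

Compound 3 `COc1ccc(C(=O)/C=C/c2cc(-c3cc(OC)c(OC)c(OC)c3)n[nH]2)cc1OC` is still to be measured in this assay. It differs from compound 1 in one place: 3,4-dimethoxyphenyl in place of 3,4-dichlorophenyl on a carbonyl carbon. Going by the values given here, since no measured pair here changes only this one place, the size of the step has to be guessed from the two numbers available. Both measured compounds, including compound 2 with its -7%, already show a strong effect at the single concentration tested, which leaves little room for a large move downward and gives no hint of a move upward. The step of a number 5 percentage points lower from compound 1 to compound 3 (within the scatter) is therefore expected to stay within the scatter. For compound 3 the expected value in this assay is 0%, with a likely range from -15% to 15%.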

Compound 3, a percentage reported as activity, at one concentration (the size of the read-out at that concentration, not a potency): -40%
Beside the measured number, compound 3's estimate is 40 percentage points above it; measured number outside the range, below it.
By their numbers in this assay, from the lowest: compound 3; then compound 2; then compound 1.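

In this assay, the group on the carbonyl carbon proves to matter a great deal: 3,4-dimethoxyphenyl in place of 3,4-dichlorophenyl gives a number 45 percentage points lower from compound 1 to compound 3 (beyond the scatter), a far stronger effect at the one concentration tested. The rest of compound 1 stays the same, and the aromatic ring of carbon only is kept in both groups, so the step follows from swapping the two chlorine atoms for two methoxy groups, which also brings in hydrogen-bond acceptors absent from the 3,4-dichlorophenyl group. No measurement here shows which feature of this swap produces the step, so the reason for its size remains unknown.

This single pair cannot show whether both methoxy groups are needed, or whether a ring carrying one methoxy group, a 3,4-diethoxyphenyl group, or a phenyl ring bearing an amine or a carboxylic acid would strengthen or weaken the effect at this place. Also open, on these data alone, are how the step would look as a true potency measured across several concentrations and whether it would recur with other groups on the rest of the core.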